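A change of ring nitrogen on a pyrimidinone arm

The source may report more compounds than this note shows. Statements on the series, on what has been measured and on what is new or still open speak of the compounds shown alone.

Among the compounds with values here, in an ADME assay on cells (Hepatocyte, Rattus norvegicus) for metabolic stability (a higher number here means faster removal of the compound, a lower number slower removal), compound 2 `CC(C)n1cc(-c2ccnc3[nH]c(C4CCN(CC(=O)N(C)C)CC4)cc23)cnc1=O` gives 100 uL/min, the highest of the two numbers known here; its only neighbour, compound 1 `CC(=O)N1CCC(c2cc3c(-c4ccc(=O)n(C(C)C)c4)ccnc3[nH]2)CC1`, gives 2.8 uL/min in this assay, a gap that lies beyond the scatter. Compound 3 `CC(C)n1cc(-c2ccnc3[nH]c(C4CCN(CC(=O)N(C)C)CC4)cc23)ccc1=O` has not been measured in this assay. It differs from compound 2 in one place: a group of 10 heavy atoms (8 carbon, 1 nitrogen, 1 oxygen; one six-membered aromatic ring with 1 hetero atom) in place of a group of 10 heavy atoms (7 carbon, 2 nitrogen, 1 oxygen; one six-membered aromatic ring with 2 hetero atoms), on an aromatic carbon. Within the data shown here, no step between two measured compounds isolates this change, so no size can be read from the data. For compound 3 a number close to compound 2 is expected, within the scatter, giving a 1.4-fold lower number from compound 2 to compound 3 (0.15 log units; within the scatter). The estimate for compound 3 in this assay is 70 uL/min, between 25 uL/min and 200 uL/min.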

Compound 3, intrinsic clearance in a liver preparation (reported as CLH), per the amount of preparation that the assay uses: 2.3 uL/min
The estimate for compound 3 lay 30-fold (1.48 log units) above the measured number; measured number outside the range, below it.
By their numbers in this assay, from the lowest: compounds 3 and 1 (each within the scatter of the next); then compound 2.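

In this assay, the whole gap sits in this one ring atom: placing the aromatic ring with 1 hetero atom on the aromatic carbon, in place of the ring with 2 hetero atoms, gives a 43-fold lower number from compound 2 to compound 3 (1.64 log units; beyond the scatter). The other change, (dimethylcarbamoyl)methyl in place of acetyl on the amine nitrogen, gives a 1.2-fold lower number from compound 1 to compound 3 (0.09 log units; within the scatter), so with this ring the two groups cannot be told apart. Nothing here explains the effect of the ring atom. Open, going by these compounds, is whether a free amine or a longer chain on that nitrogen would keep the number this low.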